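Swapping a Hydroxyphenyl for an Aminophenyl Against HL-60 Cells

The source may hold more compounds than are shown below. What is called first, only, known or untested is meant among the compounds shown, and "the series" means these compounds.

Three compounds share one core and differ only in the group carried on a nitrogen on an aromatic ring. Compound 1 `Fc1ccc(Nc2nc(-c3cccc(F)c3)nc3ccc(F)cc23)cc1` bears a 4-fluorophenyl there, compound 2 `Fc1cccc(-c2nc(Nc3cccc(Cl)c3)c3cc(F)ccc3n2)c1` a 3-chlorophenyl, and compound 3 `Oc1ccc(Nc2nc(-c3cccc(F)c3)nc3ccc(F)cc23)cc1` a 4-hydroxyphenyl. In a functional assay on HL-60 cells (Homo sapiens) for cytotoxicity, read by MTT assay, with a stated time of 48 h (on this read-out higher numbers stand for weaker inhibition and lower numbers for stronger inhibition), compound 1 gives > 50000 nM, which is a limit of the assay rather than a number. Compound 2 likewise gives > 50000 nM, again a limit. Compound 3 stands at > 50000 nM, also a limit, so its place among the measured compounds cannot be told apart from the others. All three measurements amount to the limit of > 50000 nM in this assay, at which 3 of the 3 values shown sit.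

Compound 4 `Nc1cccc(Nc2nc(-c3cccc(F)c3)nc3ccc(F)cc23)c1` is not yet measured. It differs from compound 3 by 3-aminophenyl in place of 4-hydroxyphenyl on a nitrogen on an aromatic ring. The measured steps that come closest are a step that the two limits leave unreadable from compound 1 to compound 3, a step that the two limits leave unreadable from compound 2 to compound 3 and a step that the two limits leave unreadable from compound 1 to compound 2; none of them yields a readable size, as all three values are limits. Within the data shown here, no step of measurable size therefore supports an expectation of change in this assay in either direction. Compound 4 is expected to sit at 50000 nM, within a range from 15000 nM to 200000 nM, most likely again reported only as a limit. The step this estimate means, a number no higher from compound 3 to compound 4 (the limit leaves the size open), is expected to be none beyond the scatter.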

Compound 4, half-maximal inhibitory concentration: > 50000 nM
Compound 4 was reported as a limit; the forecaster's own chance of this, stated with the estimate: 85%; the middle value sits exactly at the limit.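

Compound 4 also gives only a limit, so no step from compound 1, compound 2 or compound 3 to compound 4 can be read, and all four compounds end at the same point: the limit of > 50000 nM in this assay, at which 4 of the 4 values shown sit.

The compounds shown leave open how strongly any of them acts on these cells, and whether changing the group on the nitrogen alters that at all.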